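From compound 2 to compound 4: allyloxy replaces but-3-en-1-yl

The compounds below may be only part of what the source reports. "The series", "measured", "known", "first", "only" and "open" are said of these compounds alone.

compound 1 `C=CCCCCOc1ccccc1-c1cnc(OCCC=C)n1C`: 33000 nM
compound 2 `C=CCCCCOc1ccccc1-c1cnc(OCCCCC=C)n1C`: 7000 nM
compound 3 `C=CCCCCOc1ncc(-c2ccccc2OC)n1C`: 9000 nM

All three values come from a functional assay on U-373MG ATCC cells (Homo sapiens) for inhibition, read by colorimetric assay and MTT assay, with a stated time of 72 h; a lower number here means a stronger inhibitor, a higher number a weaker inhibitor. In this small set, compound 2 stands level with compound 3 and clearly under compound 1. Compound 4 `C=CCCCCOc1ccccc1-c1cnc(OCCOCC=C)n1C` keeps the core of compound 2 and alters only one chain: allyloxy in place of but-3-en-1-yl on a saturated chain carbon, two bonds along the chain from an oxygen on an aromatic ring. Allyloxy thus takes the place of but-3-en-1-yl.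

Going by the values given here, two measured steps touch this chain. Putting but-3-en-1-yl in place of vinyl gave a 4.7-fold lower number from compound 1 to compound 2 (0.67 log units; beyond the scatter), a modest step. Putting hydrogen in place of pent-4-en-1-yl gave a 1.3-fold higher number from compound 2 to compound 3 (0.11 log units; within the scatter). Neither step tests allyloxy directly, so they give only a rough guide. Even removing most of the chain gave a 1.3-fold higher number from compound 2 to compound 3 (0.11 log units; within the scatter), so only a small rise in the number is expected, with little confidence in its direction. The expected step is a 1.7-fold higher number from compound 2 to compound 4 (0.23 log units; within the scatter). Compound 4 is estimated at 12000 nM, with an expected range from 5000 nM to 30000 nM.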

Compound 4, half-maximal inhibitory concentration: 60000 nM
The estimate for compound 4 lay 5.0-fold (0.70 log units) below the measured number; measured number outside the range, above it.
By their numbers in this assay, from the lowest: compounds 2 and 3 (each within the scatter of the next); then compounds 1 and 4 (each within the scatter of the next).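

In this assay, this chain position proves sensitive to a small change: allyloxy in place of but-3-en-1-yl gave an 8.6-fold higher number from compound 2 to compound 4 (0.93 log units; beyond the scatter), although both groups hold 4 heavy atoms and differ in that allyloxy has 3 carbons and 1 oxygen, where but-3-en-1-yl has 4 carbons. Allyloxy in place of vinyl gave a 1.8-fold higher number from compound 1 to compound 4 (0.26 log units; within the scatter), so compound 4 goes against the earlier reading from compound 1 and compound 2 that a longer chain here brings a lower number. Nothing measured here gives a reason for the rise seen with allyloxy.

As far as these compounds go, whether the effect depends on where the oxygen sits along the chain remains open. So does how an amine in that place, or a chain longer than hex-5-en-1-yl, would change the number.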